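The source may report more compounds than this note shows. Statements on the series, on what has been measured and on what is new or still open speak of the compounds shown alone.

So far two compounds carry numbers in a functional assay on KB cells (Homo sapiens) for cytotoxicity; a lower number here means a stronger inhibitor, a higher number a weaker inhibitor. Compound 1 (`CC(C)(C)c1ccc(Cn2cc(C#N)c3c(N)ncnc32)cc1`) gives 3000 nM, and compound 2 (`Cc1ccc(Cn2cc(C(=N)S)c3c(N)ncnc32)cc1`) gives 65000 nM, the higher of the two numbers and beyond the scatter from compound 1. Compound 3 (`CC(C)(C)c1ccc(Cn2cc(C(=N)S)c3c(N)ncnc32)cc1`) differs from compound 2 in one place: tert-butyl in place of methyl on an aromatic carbon, para to a large group (tert-butyl in place of methyl on an aromatic carbon). Going by the values given here, no measured pair isolates this change, so its size remains a judgement. Compound 1 carries the same tert-butyl and reads 3000 nM, which suggests a lower number for compound 3, although compound 1 also differs from compound 2 elsewhere. The expected change, beyond the scatter, is a 6.5-fold lower number from compound 2 to compound 3 (0.81 log units; beyond the scatter). Compound 3 is estimated at 10000 nM, with an expected range of 2000 nM to 45000 nM.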

Compound 3, half-maximal inhibitory concentration: 7000 nM
Compound 3: middle estimate off by 1.4-fold (0.15 log units), on the high side, and the stated range covers the measured number.
By their numbers in this assay, from the lowest: compound 1; then compound 3; then compound 2.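

In this assay, tert-butyl in place of methyl on an aromatic carbon, para to a large group, gives a 9.3-fold lower number from compound 2 to compound 3 (0.97 log units; beyond the scatter) with the rest of the molecule unchanged, so this position now has a directly measured step beyond the scatter. With tert-butyl held constant, the other single-place change, the group of 3 heavy atoms in place of the group of 2 heavy atoms on an aromatic carbon, gives a 2.3-fold higher number from compound 1 to compound 3 (0.37 log units; beyond the scatter) and shows that this second site also affects the reading. No available evidence bears on the origin of either step.

The compounds shown leave open how ethyl or isopropyl would read at the position para to a large group, and so whether the number falls progressively between methyl and tert-butyl. They also leave open whether the methyl to tert-butyl step carries over when nitrile occupies the other site, or how an amide or carboxylic acid would read there.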